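Amide nitrogen substituent: ethyl to pyrazolyl in compound 1 series

A few compounds are considered here, and "the series" means these few. Any claim that something is new, unique, unknown or untested is made for them only; others in the source may bear on it.

Measured so far in an assay on HEK293 cells for agonist activity at transient receptor potential cation channel subfamily M member 8 (Homo sapiens), read by fluorescence and calcium flux, with a stated time of 15 min; on this read-out higher numbers stand for an effect only at larger amounts of compound and lower numbers for an effect already at smaller amounts:
- compound 1, `CCN(Cc1cccs1)C(=O)c1cc2cc(C)ccc2o1`: 120 nM
- compound 2, `CCN(Cc1cccs1)C(=O)COc1ccc(C(C)C)cc1`: 397 nM

Compound 1 gives the lowest of the two numbers in this assay; compound 2 stands higher, and the gap between the two lies beyond the usual scatter. The two differ in more than one place, so nothing is drawn from that pair beyond what the two values show.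

Compound 3, `Cc1ccc2oc(C(=O)N(Cc3cccs3)c3ccn[nH]3)cc2c1`, is not yet measured. It differs from compound 1 in one place: 1H-pyrazol-5-yl in place of ethyl on an amide-type nitrogen. Among the compounds with values here, no measured pair isolates a change of this kind, so no step between measured compounds guides the expectation. The step from compound 1 to compound 3 is expected to be small and toward higher numbers, about at the edge of the scatter, a 2.1-fold higher number from compound 1 to compound 3 (0.32 log units; beyond the scatter). Going by these compounds, compound 3 is thus estimated at 250 nM, with a range from 60 nM to 1000 nM; the range is wide, as the change is untested here.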

Compound 3, half-maximal effective concentration: 40 nM
Estimate against measurement, compound 3: 6.3-fold (0.80 log units) above; measured number outside the range, below it.
By their numbers in this assay, from the lowest: compound 3; then compound 1; then compound 2.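

The amide-type nitrogen in this series is not limited to a small saturated chain: in this assay, 1H-pyrazol-5-yl in place of ethyl gives a 3.0-fold lower number from compound 1 to compound 3 (0.48 log units; beyond the scatter), a modest step that lies beyond the scatter. The position therefore accepts a five-membered aromatic ring with a hydrogen-bond donor and acceptor, and the number moves down, something compound 1 and compound 2 could not show as they differ in more than one place. Within the data shown here, nothing at hand bears on the reason for this step, and the single pair does not separate the effect of the ring from that of its nitrogen atoms.

Open, going by these compounds, is how a phenyl ring, or a pyrazole with a methyl group on its ring nitrogen, would compare at this position. Also open, on these data alone, is whether the same change would carry over to compound 2.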